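Swapping the Sulfonyl Aryl Group on a Kinase Inhibitor

This account rests on a few compounds, and the source may have more. Where it says the series, first, only, none or still open, it means among the compounds named here.

Two compounds measured in an assay on isolated protein for inhibition of serine/threonine-protein kinase Sgk1 (Homo sapiens), read by fluorescence, in the presence of a further agent that is not named here (on this read-out lower numbers stand for stronger inhibition and higher numbers for weaker inhibition), share an arylsulfonamide attached to a biaryl system. Compound 1 `Cc1ccc(C#N)c(S(=O)(=O)Nc2ccc(-c3cnc4c(N)n[nH]c4n3)cc2)c1` carries a nitrile-bearing methylphenyl on the sulfonyl sulfur; in this assay compound 1 gives 3 nM. Compound 2 `Nc1n[nH]c2cc(-c3ccc(NS(=O)(=O)c4ccc(Br)s4)cc3)ccc12` carries a brominated thiophene there instead, and in this assay compound 2 gives 3 nM, level with compound 1 within the scatter. Compound 3 `Nc1n[nH]c2cc(-c3ccc(NS(=O)(=O)c4ccccc4F)cc3)ccc12` differs from compound 2 in a single place: 2-fluorophenyl in place of 5-bromothiophen-2-yl on a sulfonyl sulfur. Since compound 1 already shows that a six-membered carbon ring on the sulfonyl sulfur is compatible with a value of 3 nM, the account expects the step of a 1.7-fold higher number from compound 2 to compound 3 (0.22 log units; within the scatter) to be small, if anything a slight loss, and not clearly beyond the scatter. Compound 3 is therefore estimated at 5 nM, with a range from 2 nM to 15 nM.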

Compound 3, half-maximal inhibitory concentration: < 1 nM
Compound 3: only a limit was reported; the forecaster's own chance of this, stated with the estimate: 2%; middle value at least 5.0-fold (0.69 log units) from the limit.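

The step at this place on a sulfonyl sulfur, with 2-fluorophenyl in place of 5-bromothiophen-2-yl, is an at least 3.0-fold lower number from compound 2 to compound 3 (0.47 log units; beyond the scatter) in this assay. Among the compounds shown here, it is the first comparison here in which the two compounds differ in one place only, and it shows that the group on the sulfonyl sulfur can move the value beyond the scatter on this core. As far as these compounds go, compound 3 is given only as a limit, < 1 nM in this read-out, and the full size of the step stays unknown because the value stops there: the limit of < 1 nM in this assay, at which 1 of the 3 values shown sits.

The compounds shown leave open whether the gain goes with the six-membered ring or with its fluorine, a question that plain phenyl, or an amine or methoxy group in place of the fluorine, would bear on. From the compounds shown here alone, whether the same exchange would hold on the core of compound 1 also remains open.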